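Methoxy in place of nitro: one measured step, one unmeasured

The compounds below may be only part of what the source reports. "The series", "measured", "known", "first", "only" and "open" are said of these compounds alone.

compound 1 `COc1ccc(-c2c[nH]c(=O)n2-c2cc(OC)c(OC)c(OC)c2)cc1OC`: > 50000 nM
compound 2 `COc1ccc(-c2c[nH]c(=O)n2-c2cc(OC)c(OC)c(OC)c2)cc1[N+](=O)[O-]`: > 50000 nM
compound 3 `COc1cc(-n2c(-c3ccc([N+](=O)[O-])cc3)cn(C(C)=O)c2=O)cc(OC)c1OC`: 32900 nM

In a functional assay on PC-3 cells (Homo sapiens) for cytotoxicity, read by MTT assay, with a stated time of 48 h (a higher number here means a weaker inhibitor, a lower number a stronger inhibitor), compound 1 gives > 50000 nM, which is a limit of the assay and not a number. Compound 2 likewise gives only a limit, > 50000 nM. Going by the values given here, compound 3 gives 32900 nM, the single number in the set.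

From compound 2 to compound 1 the change is methoxy in place of nitro on an aromatic carbon. Its step, a step that the two limits leave unreadable from compound 2 to compound 1, cannot be read because both values sit at the limit of > 50000 nM in this assay, at which 2 of the 3 values shown sit. The difference between the cores of compound 2 and compound 3 is not broken down here.

Compound 4 `COc1ccc(-c2cn(C(C)=O)c(=O)n2-c2cc(OC)c(OC)c(OC)c2)cc1` is not yet measured. From compound 3 it differs by methoxy in place of nitro on an aromatic carbon, the same kind of change, though the place differs: para to a large group, against ortho to a methoxy group and meta to a large group. The measured step gives no size, so the expectation rests on compound 3 at 32900 nM. It also rests on (the limit of > 50000 nM in this assay, at which 2 of the 3 values shown sit). Compound 4 is expected to show a 1.4-fold higher number from compound 3 to compound 4 (0.14 log units; within the scatter) in this assay. Compound 4 is estimated at 45000 nM, between 15000 nM and 150000 nM, with a real chance of a limit only.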

Compound 4, half-maximal inhibitory concentration: 19700 nM
The estimate for compound 4 lay 2.3-fold (0.36 log units) above the measured number, within the range that was stated.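

In this assay, methoxy in place of nitro on the core of compound 3 gives a 1.7-fold lower number from compound 3 to compound 4 (0.22 log units; within the scatter), so on this core the change shows no effect beyond the scatter. This does not show that the change carries from one core to another, as the same kind of change also sits at a different place on the other core. The step from compound 2 to compound 1 cannot be read, since both values are limits of the assay and not numbers: the limit of > 50000 nM in this assay, at which 2 of the 4 values shown sit.

Still open, on these data alone, is whether an amine or a carboxylic acid, para to a large group, would give a step beyond the scatter on the core of compound 3. As far as these compounds go, the contribution of the difference between the core of compound 2 and the core of compound 3 also stays open.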